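Swapping carbamoyl for 3-cyanophenyl on a shared core

The compounds below may be only part of what the source reports. "The series", "measured", "known", "first", "only" and "open" are said of these compounds alone.

Compound 1 `NC(=O)Cn1c(=O)n(C2OC(CO)[C@@H](O)[C@H]2O)c2nc(N)nc(O)c21` gives 42% in a functional assay on YAC-1 cells (Mus musculus) (a higher number here means a larger maximal response, a lower number a smaller maximal response), the highest of the three values recorded. Compound 2 `C=CCn1c(=S)n(COCCO)c2nc(N)nc(O)c21` gives 28% in this assay, a value beyond the scatter below compound 1, and compound 3 `C=CCn1c(=O)n([C@H]2CO[C@@H](CO)C2)c2nc(N)nc(O)c21` gives 0% in this assay, the furthest below. Compound 4 `N#Cc1cccc(Cn2c(=O)n(C3OC(CO)[C@@H](O)[C@H]3O)c3nc(N)nc(O)c32)c1` has not been measured; it differs from compound 1 in one place: 3-cyanophenyl in place of carbamoyl on a saturated chain carbon bound to an aromatic nitrogen. Within the data shown here, no measured pair shows this change, so its effect is unknown. Compound 4 is expected to give a smaller maximal response than compound 1, with a moderate step of a number 17 percentage points lower from compound 1 to compound 4 (beyond the scatter) beyond the scatter. Compound 4 is estimated at 25%, within the range 0% to 55%.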

Compound 4, largest response reached (reported as maximal response), in percent of the reference or control that the assay uses: 11%
Compound 4: the middle estimate sits 14 percentage points above what was measured, and the stated range covers the measured number.
By their numbers in this assay, from the lowest: compound 3; then compound 4; then compound 2; then compound 1.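

Among these compounds, the swap is the first single-place change read at this position, and in this assay it gives a large step, a number 31 percentage points lower from compound 1 to compound 4 (beyond the scatter), so the response of this series is sensitive to the group carried on a saturated chain carbon bound to an aromatic nitrogen. Carbamoyl gives the larger maximal response of the two groups compared on this core. Nothing available explains the drop.

Going by these compounds, it remains open whether the phenyl ring or the nitrile accounts for the step, which an unsubstituted phenyl would separate. On these data alone, how a carboxylic acid or an amine would compare with carbamoyl also remains open.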